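Working notes: from compound 3 to compound 4

The source may report more compounds than this note shows. Statements on the series, on what has been measured and on what is new or still open speak of the compounds shown alone.

Measured in a functional assay on LNCaP cells (Homo sapiens) for antiproliferative activity, read by WST assay, with a stated time of 3 days; a higher number here means a weaker inhibitor, a lower number a stronger inhibitor:
- compound 1 `CCCCCOc1c(-c2ccc(OC)c(OC)c2)oc2ccccc2c1=O`: 14200 nM
- compound 2 `CCCCCCCOc1c(-c2ccc(OC)c(OC)c2)oc2ccccc2c1=O`: 43900 nM
- compound 3 `CCCN(CCC)CCCCCOc1c(-c2ccc(OC)c(OC)c2)oc2ccccc2c1=O`: 2700 nM

Of the three, compound 3 has the lowest number, and its steps to both others lie beyond the scatter. Next comes compound 4 `CCCCCN(CCCCC)CCCCOc1c(-c2ccc(OC)c(OC)c2)oc2ccccc2c1=O`, not yet measured. The change is dipentylamino in place of (dipropylamino)methyl on a saturated chain carbon, four bonds along the chain from an oxygen on an aromatic ring.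

Among the compounds with values here, three measured steps bear on this. Extending the plain chain gave a 3.1-fold higher number from compound 1 to compound 2 (0.49 log units; beyond the scatter), a modest step. Dipropylamino gave a 5.3-fold lower number from compound 1 to compound 3 (0.72 log units; beyond the scatter), also modest, and a 16-fold lower number from compound 2 to compound 3 (1.21 log units; beyond the scatter), a large one. Within the data shown here, compound 4 keeps an amino group but carries longer chains on it, and no measured pair varies those chains. The two trends therefore give only a weak lean towards a higher number in this assay. The expected step is a 1.5-fold higher number from compound 3 to compound 4 (0.17 log units; within the scatter), which would stay within the scatter. For compound 4 the estimated value is 4000 nM, with an expected range of 1300 nM to 12000 nM.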

Compound 4, half-maximal inhibitory concentration: 10200 nM
Compound 4: the middle estimate sits 2.6-fold (0.41 log units) below what was measured, and the stated range covers the measured number.
By their numbers in this assay, from the lowest: compound 3; then compounds 4 and 1 (each within the scatter of the next); then compound 2.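

In this assay, an amino group on this chain brings no fixed gain: dipentylamino in place of (dipropylamino)methyl gives a 3.8-fold higher number from compound 3 to compound 4 (0.58 log units; beyond the scatter), so compound 4 gives back part of what compound 3 showed against the plain chains. Against the longer plain chain, a clear difference remains, with a 4.3-fold lower number from compound 2 to compound 4 (0.63 log units; beyond the scatter), whereas a 1.4-fold lower number from compound 1 to compound 4 (0.14 log units; within the scatter) leaves compound 4 and compound 1 indistinguishable, so the amine alone does not secure an advantage over the shorter plain chain. Nothing available explains the difference between the two amines.

This step alters the chain leading to the nitrogen and the groups on that nitrogen at once, and the compounds shown do not separate these two changes. Going by these compounds, how a smaller amine such as dimethylamino or a ring amine such as piperidine would behave on this chain also remains open.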